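Compound 3 and the Limit of the Series

A few compounds are considered here, and "the series" means these few. Any claim that something is new, unique, unknown or untested is made for them only; others in the source may bear on it.

In a functional assay on HCT-15 cells (Homo sapiens) for antiproliferative activity (a higher number here means a weaker inhibitor, a lower number a stronger inhibitor), compound 1 (`COc1ccc(S(=O)(=O)Oc2ccccc2NC(=O)Nc2ccccc2)cc1`) gives > 10000 nM, which is a limit of the assay and not a number. Compound 2 (`COc1ccc(S(=O)(=O)Oc2ccccc2NC(=O)c2ccc(N(C)C)cc2)cc1`) gives > 10000 nM, again a limit and not a number. Compound 2 therefore has no measured potency to build on. Compound 3 (`COc1ccc(S(=O)(=O)Oc2ccccc2NC(=O)Oc2ccccc2)cc1`) differs from compound 2 at one place: phenoxy in place of 4-(dimethylamino)phenyl on a carbonyl carbon. Within the data shown here, only one measured step bears on this change, a step that the two limits leave unreadable from compound 1 to compound 2, and its size cannot be read. The evidence so far is the limit of > 10000 nM in this assay, at which 2 of the 2 values shown sit. Among the measured compounds shown here, with no sized step available, no change beyond the scatter is expected in this assay, and no direction can be assigned. The expected step is a number no higher from compound 2 to compound 3 (the limit leaves the size open). Compound 3 is expected to give about 10000 nM. The estimated range for compound 3 runs from 4000 nM to 30000 nM.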

Compound 3, half-maximal inhibitory concentration: > 10000 nM
Compound 3: no number, only a limit (the forecaster's own chance of this, stated with the estimate: 70%); the middle value sits exactly at the limit.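

In this assay compound 3 gives > 10000 nM, a limit and not a number. Among these compounds, no step among compound 1, compound 2 and compound 3 can be read. The compounds shown leave open whether any change at this carbonyl carbon gives a measurable potency in this assay.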